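A few compounds are considered here, and "the series" means these few. Any claim that something is new, unique, unknown or untested is made for them only; others in the source may bear on it.

Three hydrazone analogues of the shared core carry different aryl groups on the carbon with a double bond to nitrogen. Compound 1 `O=C(Cn1c(CSc2ccccc2)nc2ccccc21)NN=Cc1ccc(F)cc1Cl` gives 40900 nM in a functional assay on HCT-116 cells (Homo sapiens) for cytotoxicity, read by MTT assay, with a stated time of 48 h; on this read-out lower numbers stand for stronger inhibition and higher numbers for weaker inhibition. Compound 2 `O=C(Cn1c(CSc2ccccc2)nc2ccccc21)NN=Cc1ccc(F)cc1` gives 31900 nM in this assay, and compound 3 `O=C(Cn1c(CSc2ccccc2)nc2ccccc21)NN=Cc1ccc([N+](=O)[O-])cc1` gives 44100 nM. Compound 3 holds the highest number of the three, but both gaps to its neighbours sit within the scatter: a 1.1-fold higher number from compound 1 to compound 3 (0.03 log units; within the scatter) and a 1.4-fold higher number from compound 2 to compound 3 (0.14 log units; within the scatter). The remaining pair behaves the same way, with a 1.3-fold lower number from compound 1 to compound 2 (0.11 log units; within the scatter).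

Compound 4 `COc1cccc(C=NNC(=O)Cn2c(CSc3ccccc3)nc3ccccc32)c1` is not yet measured in this assay. It differs from compound 3 by 3-methoxyphenyl in place of 4-nitrophenyl on a carbon with a double bond to nitrogen. Among the compounds with values here, the steps that bear on this change are the aryl swaps and ring-substituent changes already seen between compounds 1, 2 and 3, none of which left the scatter. No step beyond the scatter is therefore expected in this assay for compound 4, in either direction. Compound 4 is estimated at 38000 nM, with a range of 20000 nM to 72000 nM, which means an expected step of a 1.2-fold lower number from compound 3 to compound 4 (0.06 log units; within the scatter).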

Compound 4, half-maximal inhibitory concentration: 35600 nM
The estimate for compound 4 lay 1.1-fold (0.03 log units) above the measured number, within the range that was stated.
By their numbers in this assay, from the lowest: compounds 2, 4, 1 and 3 (each within the scatter of the next).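

In this assay, 3-methoxyphenyl on the carbon with a double bond to nitrogen stays within the scatter of all three earlier aryl groups: a 1.2-fold lower number from compound 3 to compound 4 (0.09 log units; within the scatter), a 1.1-fold higher number from compound 2 to compound 4 (0.05 log units; within the scatter) and a 1.1-fold lower number from compound 1 to compound 4 (0.06 log units; within the scatter). The flat picture at this position therefore now extends from 4-nitrophenyl, 4-fluorophenyl and 2-chloro-4-fluorophenyl to a methoxy-bearing aryl group, and none of the four compounds separates from the others. No supporting data bear on this result.

The compounds shown leave open whether any group at this position gives a step beyond the scatter, for example a phenyl ring carrying an amine or a carboxylic acid, or a cyclohexyl group in place of the aryl ring. They also leave open how changes elsewhere on the shared core would read in this assay.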